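This account rests on a few compounds, and the source may have more. Where it says the series, first, only, none or still open, it means among the compounds named here.

In a physicochemical assay for permeability, using PAMPA (a lower number here means that the compound crosses the layer more slowly, a higher number that the compound crosses the layer faster), compound 1 `O=C(O)CCn1c(=O)oc2cc(OCC3CCC3)c(Cl)cc21` gives 12 nm/s. On these data alone, compound 2 `COc1cc2oc(=O)n(CCC(=O)O)c2cc1Cl` gives < 3 nm/s, which is a limit of the assay and not a number, so its exact standing is unknown. Compound 3 `C[C@@H](Oc1cc2oc(=O)n(CCC(=O)O)c2cc1Cl)c1ncccn1` differs from compound 2 by a group of 8 heavy atoms (6 carbon, 2 nitrogen; one six-membered aromatic ring with 2 hetero atoms) in place of one carbon atom, on an oxygen on an aromatic ring. Going by the values given here, the only measured step that bears on this change is an at least 4.0-fold lower number from compound 1 to compound 2 (0.60 log units; beyond the scatter), with hydrogen in place of cyclobutyl on a saturated chain carbon bound to an oxygen on an aromatic ring. Read in reverse, that step links the larger group of compound 1 to the higher number. Among the compounds with values here, the group entering compound 3 is not the one in compound 1, however, so this guide is loose. The expected change is an at least 1.6-fold higher number from compound 2 to compound 3 (0.22 log units; that floor lies within the scatter), towards a higher number, although a result at the limit remains possible. For compound 3 the estimated value is 5 nm/s, with a range of 2 nm/s to 14 nm/s.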

Compound 3, apparent permeability: < 3 nm/s
Compound 3: a limit, no number (the forecaster's own chance of this, stated with the estimate: 35%); middle value at least 1.6-fold (0.22 log units) from the limit.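

In this assay compound 3 gives < 3 nm/s, which is a limit of the assay and not a number. The step between compound 2 and compound 3 cannot be read, as both values are limits. Going by these compounds alone, the one readable comparison is an at least 4.0-fold lower number from compound 1 to compound 3 (0.60 log units; beyond the scatter), which shows that on this oxygen a group with more heavy atoms than the one in compound 1 does not keep the number of compound 1, so heavy-atom count alone does not set the read-out across these compounds.

Still open, on these data alone, is whether the hetero atoms of the ring or the defined stereocentre separate compound 3 from compound 1. Also open is how a plain phenyl ring or a longer carbon chain on this oxygen would read against the floor of the assay: the limit of < 3 nm/s in this assay, at which 2 of the 3 values shown sit.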